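The compounds below may be only part of what the source reports. "The series", "measured", "known", "first", "only" and "open" are said of these compounds alone.

Working notes on the series. Of the compounds shown here, two have numbers so far. Compound 1 `O=C(O)c1cc(-c2ccc(C3CCNCC3)cc2)cc(-c2cn(-c3ccc(C(F)(F)F)cc3)nn2)c1` in a functional assay on the whole organism (strain ICR) for inhibition, with Mus musculus as the target, with stated times of 7 days and 3 h, at a dose of 10 umol/kg by the intraperitoneal route (on this read-out higher numbers stand for more inhibition at the one dose given (going by the name of the read-out) and lower numbers for less inhibition), gives 55.1%. Compound 2 `NCCCNC(=O)c1ccc(-c2cc(C(=O)O)cc(-n3cc(-c4ccc(C(F)(F)F)cc4)nn3)c2)s1` in this assay gives 30.9%, the lowest of the two numbers; the nearest number is that of compound 1, which stands higher by an amount beyond the scatter. Among the compounds with values here, no pair that differs in a single place has been measured, so no step is known.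

Compound 3 `O=C(O)c1cc(-c2ccc(C3CCNCC3)cc2)cc(-n2cc(-c3ccc(C(F)(F)F)cc3)nn2)c1` is not yet measured. Compared with compound 2, (4-(piperidin-4-yl)phenyl in place of 5-((3-aminopropyl)carbamoyl)thiophen-2-yl on an aromatic carbon). Compound 3 thereby carries the same 4-(piperidin-4-yl)phenyl group as compound 1 and stands close to compound 1 in structure, which is the main ground for the expectation below.

Because compound 1 gives 55.1% and compound 2 gives 30.9%, the step expected a number 17.1 percentage points higher from compound 2 to compound 3 (beyond the scatter) is upward and beyond the scatter, the number of compound 3 being expected to come closer to that of compound 1 than to that of compound 2. Compound 3 is therefore estimated at 48%, with a range from 30% to 65%; a reported limit instead of a number is not expected in this read-out.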

Compound 3, a percentage reported as inhibition, in the whole organism at one dose (the size of the read-out at that dose, not a potency): 31.9%
The estimate for compound 3 lay 16.1 percentage points above the measured number, and the stated range covers the measured number.
By their numbers in this assay, from the lowest: compounds 2 and 3 (each within the scatter of the next); then compound 1.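

In this assay, the change on this aromatic carbon, meta to a carboxy group, gives a number 1 percentage points higher from compound 2 to compound 3 (within the scatter) when 4-(piperidin-4-yl)phenyl takes the place of 5-((3-aminopropyl)carbamoyl)thiophen-2-yl. The two groups match in heavy-atom count but differ in make-up: the group leaving holds a five-membered aromatic ring with 1 hetero atom and a double bond outside aromatic rings, and the group entering holds a six-membered non-aromatic ring with 1 hetero atom and a six-membered aromatic ring of carbon only, yet at the one dose given this position does not tell them apart. No supporting measurement bears on this result, and it remains unexplained.

Open, from the compounds shown here alone, is whether a plain phenyl, with no piperidine ring, or a thiophene with a free carboxylic acid in place of the amide chain would stand with these two compounds in this assay or apart from them. Also open, going by these compounds, is whether a longer chain than 3-aminopropyl, or a primary amine placed directly on the phenyl, would give a number beyond the scatter at this position.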